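A few compounds are considered here, and "the series" means these few. Any claim that something is new, unique, unknown or untested is made for them only; others in the source may bear on it.

Compound 1 `Nc1nc(N)c2c(-c3ccoc3)cn([C@@H]3O[C@H](CO)[C@@H](O)[C@H]3O)c2n1` — > 20000 nM
Compound 2 `COc1nc(N)nc2c1c(-c1ccccc1)cn2[C@@H]1O[C@H](CO)[C@@H](O)[C@H]1O` — > 20000 nM
Compound 3 `COc1ncnc2c1c(-c1ccoc1)cn2[C@@H]1O[C@H](CO)[C@@H](O)[C@H]1O` — 290 nM

In a functional assay on HepG2 cells (Homo sapiens) for antiproliferative activity, read by XTT assay, with a stated time of 72 h (a higher number here means a weaker inhibitor, a lower number a stronger inhibitor), compound 1 gives > 20000 nM; this is a limit of the assay and not a number. Compound 2 likewise returns only a limit in this assay, > 20000 nM. Among the compounds with values here, compound 3 is the one compound with an actual figure, 290 nM. Within the data shown here, that is where compound 3 stands: the only number among the three, as the limit of > 20000 nM in this assay, at which 2 of the 3 values shown sit, records.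

Compound 4 `COc1nc(N)nc2c1c(-c1ccoc1)cn2[C@@H]1O[C@H](CO)[C@@H](O)[C@H]1O` has not yet been measured in this assay. It differs from compound 3 by amino in place of hydrogen on an aromatic carbon. No step between two measured compounds is shown, so nothing here measures this change directly. Still, compound 1 and compound 2 both carry an amino group on their core and both sit at the limit, while compound 3 lacks it and has a number. On that basis the step of a 69-fold higher number from compound 3 to compound 4 (1.84 log units; beyond the scatter) is expected to run toward weaker inhibition, well beyond the scatter. The estimate for compound 4 is 20000 nM, in a range from 3000 nM to 60000 nM, with a fair chance that the assay returns only a limit.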

Compound 4, half-maximal inhibitory concentration: > 20000 nM
Compound 4 was reported as a limit (the forecaster's own chance of this, stated with the estimate: 65%); the middle value sits exactly at the limit.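

In this assay, within the data shown here, amino in place of hydrogen on an aromatic carbon, at the place between two ring nitrogen atoms, gives an at least 68-fold higher number from compound 3 to compound 4 (1.83 log units; beyond the scatter), a direct measure of this change where the earlier compounds offered only an indirect hint. With the methoxy group, the furan-3-yl group and the sugar held constant, this one pair shows that compound 3, with hydrogen at this position, has a real figure, whereas compound 4, with amino there, does not, so the loss of activity can be tied to this change alone. The steps to compound 4 from compound 2 and from compound 1 cannot be read, since both ends of each are limits, and the limit now covers most of the set: the limit of > 20000 nM in this assay, at which 3 of the 4 values shown sit.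

On these data alone, how far the true value of compound 4 lies past the limit stays unknown, so the step gives only a minimum size. As far as these compounds go, it also remains open whether a methyl group, a chlorine atom or a methylamino group at this same place would keep the activity of compound 3, and whether amino has the same effect when the methoxy group or the furan-3-yl group is exchanged.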